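A few compounds are considered here, and "the series" means these few. Any claim that something is new, unique, unknown or untested is made for them only; others in the source may bear on it.

Measured in a functional assay on U-937/GTB cells (Homo sapiens) for cytotoxicity; a higher number here means a weaker inhibitor, a lower number a stronger inhibitor:
Compound 1 `CO/N=c1\[nH]cnc2c1[n+](C/C=C(\C)CCC=C(C)C)cn2C`: 17500 nM
Compound 2 `CC(C)=CCC/C(C)=C\CC/C(C)=C/C[n+]1cn(C)c2nc[nH]/c(=N\OCc3ccccc3)c21`: 7550 nM
Compound 3 `CO/N=c1\[nH]cnc2c1[n+](C/C=C(\C)CC/C=C(\C)CC/C=C(\C)CCC=C(C)C)cn2C(C)C`: 1100 nM

Compound 3 has the lowest number of the three, and both other compounds lie above it by more than the usual scatter, so it is the strongest inhibitor of this set. Compound 4 `CO/N=c1\[nH]cnc2c1[n+](C/C=C(\C)CC/C=C(\C)CC/C=C(\C)CCC=C(C)C)cn2CCC#N` has 2-cyanoethyl in place of isopropyl on an aromatic nitrogen. For the measured compounds named here, no measured pair of compounds shows this change alone, so the expectation is tentative. In this assay, no step beyond the scatter is expected, with a slight lean towards a higher number, meaning a weaker inhibitor. The estimated step is a 1.8-fold higher number from compound 3 to compound 4 (0.26 log units; within the scatter). The expected value for compound 4 is 2000 nM, with an estimated range of 750 nM to 6000 nM.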

Compound 4, half-maximal inhibitory concentration: 3330 nM
Compound 4: the middle estimate sits 1.7-fold (0.22 log units) below what was measured; measured number inside the range.
By their numbers in this assay, from the lowest: compound 3; then compound 4; then compound 2; then compound 1.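

In this assay the group on this aromatic nitrogen matters: 2-cyanoethyl in place of isopropyl weakens the inhibitor modestly but beyond the scatter (a 3.0-fold higher number from compound 3 to compound 4 (0.48 log units; beyond the scatter)). For the compounds shown here, the earlier compounds differed in several places at once, so this is the only single change that can be read here. Nothing available explains this step.

Only these two groups can be compared at this position. On these data alone, whether a longer chain such as butyl, an amine or a carboxylic acid on this nitrogen would keep the strength of compound 3 remains open.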